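Methoxy for Methyl on the Shared Core

A few compounds are considered here, and "the series" means these few. Any claim that something is new, unique, unknown or untested is made for them only; others in the source may bear on it.

Compound 1 `COc1ccc(Nc2nc(-c3ccccn3)cs2)cc1OC` and compound 2 `Cc1ccc(Nc2nc(-c3ccccn3)cs2)nc1` share a core. In a physicochemical assay for solubility, in phosphate buffer, with a stated time of 2 h, at pH 7.4 (a lower number here means a less soluble compound, a higher number a more soluble compound), compound 1 gives 10000 nM. Compound 2 gives 10000 nM in the same assay, level with compound 1 within the scatter. Compound 3 `COc1ccc(Nc2nc(-c3ccccn3)cs2)nc1` has methoxy in place of methyl on an aromatic carbon of compound 2: methoxy in place of methyl on an aromatic carbon. Within the data shown here, no measured pair shows this change, so no step beyond the scatter is expected in this assay. The estimated step is no change at the digits printed from compound 2 to compound 3 (within the scatter). For compound 3 the estimated value is 10000 nM, with an expected range of 5000 nM to 16000 nM.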

Compound 3, solubility: 40000 nM
Estimate against measurement, compound 3: 4.0-fold (0.60 log units) below, outside the stated range (above it).
By their numbers in this assay, from the lowest: compounds 1 and 2 (each within the scatter of the next); then compound 3.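

At this position, on an aromatic carbon two atoms from the ring nitrogen and para to a large group, methoxy in place of methyl gives a 4.0-fold higher number from compound 2 to compound 3 (0.60 log units; beyond the scatter) in this assay. This is the first step beyond the scatter among the compounds shown, and it comes from a change in one place, so the number can move at this position.

As far as these compounds go, whether an amine or a longer chain on the same carbon would move the number further remains open, as does whether this single pair holds on other cores. Nothing measured here bears on why the step arises.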